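Compound 4: a carbonyl enters at the limit

The source may hold more compounds than are shown below. What is called first, only, known or untested is meant among the compounds shown, and "the series" means these compounds.

Measured in a functional assay on SGC-7901 cells (Homo sapiens) for antiproliferative activity, read by MTT assay, with a stated time of 24 h; a lower number here means a stronger inhibitor, a higher number a weaker inhibitor:
Compound 1 `O=C(NNc1cccc(Cl)c1)c1ccc(NS(=O)(=O)c2cnc(O)nc2O)cc1`: 11600 nM
Compound 2 `O=C(NNc1ccccc1F)c1ccc(NS(=O)(=O)c2cnc(O)nc2O)cc1`: 16000 nM
Compound 3 `Cc1cccc(NNC(=O)c2ccccc2NS(=O)(=O)c2cnc(O)nc2O)c1`: > 20000 nM (a limit)

Compound 3 has no number in this assay. Its reading of > 20000 nM is a limit of the assay. For the measured compounds named here, it is the only compound of the three there, which makes this (the limit of > 20000 nM in this assay, at which 1 of the 3 values shown sits).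

Compound 4 `Cc1ccc(C(=O)NNC(=O)c2ccccc2NS(=O)(=O)c2cnc(O)nc2O)cc1` has not yet been measured. It carries (4-methylphenyl)carbonyl in place of 3-methylphenyl on an amine nitrogen, whose other neighbour is an amide-type nitrogen: (4-methylphenyl)carbonyl in place of 3-methylphenyl on an amine nitrogen.

Going by the values given here, only one measured step is available, a 1.4-fold higher number from compound 1 to compound 2 (0.14 log units; within the scatter). It lies within the scatter and adds no carbonyl, so it offers only weak guidance and gives no sign of a large move for this different change. No measurement shows what the entering carbonyl does.

The expectation therefore starts from compound 3 and its limit of > 20000 nM. No step beyond the scatter is expected in this assay, and no direction can be favoured, so the estimated step is a step that the limit leaves unreadable from compound 3 to compound 4. A reading at the same limit is quite likely. For compound 4 the expected value is 22000 nM, with an estimated range from 11000 nM to 45000 nM.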

Compound 4, half-maximal inhibitory concentration: 15500 nM
The estimate for compound 4 lay 1.4-fold (0.15 log units) above the measured number; the range from low to high includes it.
By their numbers in this assay, from the lowest: compounds 1, 4 and 2 (each within the scatter of the next). At a limit, above all of these: compound 3.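

In this assay, putting (4-methylphenyl)carbonyl in place of 3-methylphenyl on the amine nitrogen gives an at least 1.2-fold lower number from compound 3 to compound 4 (0.11 log units; that floor lies within the scatter). For the compounds shown here, this is the first view of a carbonyl at this position, since the only earlier step, a 1.4-fold higher number from compound 1 to compound 2 (0.14 log units; within the scatter), swapped one aryl group for another and brought in no carbonyl; with the carbonyl in place, compound 4 gives a readable number rather than a limit. Even so, the step shows no gain beyond the scatter, and its true size cannot be read because compound 3 stands at a limit of the assay: the limit of > 20000 nM in this assay, at which 1 of the 4 values shown sits.

The change also alters two things at once, as the carbonyl enters while the methyl group's printed position goes from 3 to 4, so the compounds shown cannot separate the effect of one from the other; (3-methylphenyl)carbonyl on the same nitrogen would isolate the carbonyl. As far as these compounds go, it also remains open how this position responds to other groups on the carbonyl, such as a carboxylic acid or an amine on the ring, or a longer chain in place of the ring.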